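A few compounds are considered here, and "the series" means these few. Any claim that something is new, unique, unknown or untested is made for them only; others in the source may bear on it.

Going by the values given here, compound 1 `Cc1cc(-c2c(C)nn(-c3nc(-c4ccc(Cl)c(Cl)c4)c(SC(C)C)s3)c2C(=O)O)cc(C)n1` is the only compound in this set with a measured number: in a functional assay on BJAB cells (Homo sapiens) for antiproliferative activity, with a stated time of 4 days (a higher number here means that more compound is needed for the effect, a lower number that less compound is needed), compound 1 gives 580 nM. Compound 2 `Cc1c(-c2cc(Cl)cc(Cl)c2)c(C(=O)O)nn1-c1nc(-c2ccncc2)c(SC(C)C)s1` is reported in this assay as "not active" (no number reported), so no number stands beside it and nothing can be said about the size of any step between compound 1 and compound 2. Compound 3 `Cc1nn(-c2nc(-c3ccc(Cl)c(Cl)c3)c(SC(C)C)s2)c(C(=O)O)c1-c1ccc(Cl)cc1` has not yet been measured. Compound 3 differs from compound 1 in one place: 4-chlorophenyl in place of 2,6-dimethylpyridin-4-yl on an aromatic carbon. Among the compounds with values here, no step between two measured compounds matches this change, so the expectation rests on compound 1 alone. With the loss of the ring nitrogen and its hydrogen-bond acceptor, a modest weakening is expected, though one that may well lie within the scatter; the estimated step from compound 1 to compound 3 in this assay is a 2.1-fold higher number from compound 1 to compound 3 (0.32 log units; beyond the scatter). For compound 3 the expected value in this assay is 1200 nM, in the range 300 nM to 5000 nM.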

Compound 3, half-maximal effective concentration: 2500 nM
Compound 3: middle estimate off by 2.1-fold (0.32 log units), on the low side, within the range that was stated.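

On an aromatic carbon of the five-membered aromatic ring with 2 nitrogen, 4-chlorophenyl in place of 2,6-dimethylpyridin-4-yl gives in this assay a 4.3-fold higher number from compound 1 to compound 3 (0.63 log units; beyond the scatter). This position therefore responds to the exchange, yet compound 3 still gives a number, so a six-membered aromatic ring of carbon only does not abolish the read-out here. Nothing measured here accounts for the size of this step.

As far as these compounds go, the exchange alters the ring nitrogen, the two methyl groups and the chlorine all at once, so which of these changes carries the step remains open. Plain phenyl, or pyridin-4-yl without its methyl groups, at this position would begin to separate these contributions, and the compounds shown do not settle how either would behave.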